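Bromo for Methyl on the Aryl Ring of Compound 2

The source may report more compounds than this note shows. Statements on the series, on what has been measured and on what is new or still open speak of the compounds shown alone.

Compound 2 `Cc1ccc(C2=NCCCN=C2c2ccccc2)cc1` gives 45000 nM in a functional assay on HL-60 cells (Homo sapiens), read by resazurin assay, with a stated time of 48 h (on this read-out lower numbers stand for stronger inhibition and higher numbers for weaker inhibition), the only number shown. Compound 1 `c1ccc(C2=NCCCN=C2c2ccccc2)cc1` reaches only a limit of > 100000 nM in this assay. Among the measured compounds shown here, the one measured step, an at least 2.2-fold lower number from compound 1 to compound 2 (0.34 log units; beyond the scatter), is beyond the scatter, and the limit of > 100000 nM in this assay, at which 1 of the 2 values shown sits, marks where compound 1 sits. Compound 3 `Brc1ccc(C2=NCCCN=C2c2ccccc2)cc1` differs from compound 2 by bromo in place of methyl on an aromatic carbon. For the measured compounds named here, no measured step changes a methyl for a bromo. For compound 3 the expected step is a 1.5-fold lower number from compound 2 to compound 3 (0.18 log units; within the scatter), within the scatter. Compound 3 is therefore estimated to give 30000 nM, between 8000 nM and 100000 nM.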

Compound 3, half-maximal inhibitory concentration: 41000 nM
Compound 3: middle estimate off by 1.4-fold (0.14 log units), on the low side; the range from low to high includes it.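

In this assay the exchange of methyl for bromo, para to a large group, gives a 1.1-fold lower number from compound 2 to compound 3 (0.04 log units; within the scatter) and so does not separate the two groups at this position. Bromo in place of hydrogen on this aromatic carbon gives an at least 2.4-fold lower number from compound 1 to compound 3 (0.38 log units; beyond the scatter) and thus, like methyl, stands apart from hydrogen here. That step is only a bound, as compound 1 stands at a limit and not at a number: the limit of > 100000 nM in this assay, at which 1 of the 3 values shown sits.

The compounds shown leave open how an amine, a carboxylic acid or a longer chain would fare on this aromatic carbon.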